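The source may hold more compounds than are shown below. What is called first, only, known or untested is meant among the compounds shown, and "the series" means these compounds.

Measured so far in a functional assay on CUTLL1 cells (Homo sapiens) for inhibition, read by resazurin assay, with a stated time of 48 h, in the absence of a further agent; on this read-out higher numbers stand for an effect only at larger amounts of compound and lower numbers for an effect already at smaller amounts:
Compound 1 `CC(C)c1nc(N)ncc1-c1ccncc1`: > 100000 nM
Compound 2 `Nc1ncc(-c2ccncc2)cn1`: > 100000 nM
Compound 3 `Nc1ncc(-c2ccncc2)c(-c2ccccc2)n1`: > 100000 nM

All three entries are limits of the assay and not numbers, and the picture so far is the limit of > 100000 nM in this assay, at which 3 of the 3 values shown sit. Compound 3 stands at > 100000 nM, which is a limit.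

The next compound, compound 4 `Nc1ncc(-c2ccncc2)c(-c2ccoc2)n1`, keeps the shared core and carries furan-3-yl in place of phenyl on an aromatic carbon, next to the ring nitrogen and ortho to a pyridin-4-yl group: furan-3-yl in place of phenyl on an aromatic carbon.

Within the data shown here, three measured steps bear on this change, since each swaps the group on that same carbon. They are a step that the two limits leave unreadable from compound 2 to compound 3, a step that the two limits leave unreadable from compound 1 to compound 3 and a step that the two limits leave unreadable from compound 1 to compound 2. None has a readable size, so no measured size can be carried over to the new group. Hydrogen, isopropyl and phenyl at this place have so far given no number at all.

With a step that the two limits leave unreadable from compound 2 to compound 3 as the nearest guide, no clear step is expected in this assay, and compound 4 will most likely also reach the limit. The estimated step is an at least 1.4-fold lower number from compound 3 to compound 4 (0.15 log units; that floor lies within the scatter). For compound 4 the estimated value is 70000 nM, with an expected range from 15000 nM to 100000 nM.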

Compound 4, half-maximal effective concentration: > 100000 nM
Compound 4: no number, only a limit (the forecaster's own chance of this, stated with the estimate: 65%); middle value at least 1.4-fold (0.15 log units) away from the limit.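

In this assay compound 4 gives > 100000 nM, which is a limit and not a number, so its steps from compound 1, compound 2 and compound 3 cannot be read. The compounds shown leave open whether any group on this aromatic carbon can give a measurable value, and the picture remains: the limit of > 100000 nM in this assay, at which 4 of the 4 values shown sit.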